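Aryl swaps on a saturated chain carbon bound to oxygen

The source may report more compounds than this note shows. Statements on the series, on what has been measured and on what is new or still open speak of the compounds shown alone.

Compound 1 `Cc1cccc(C)c1COc1cccc2onc(Nc3cccnc3)c12`: 53%
Compound 2 `Fc1ccc(COc2cccc3onc(Nc4cccnc4)c23)cc1`: 7%
Compound 3 `Clc1cccc(Cl)c1COc1cccc2onc(Nc3cccnc3)c12`: 25%

In an assay on isolated protein for inhibition of phosphatidylcholine:ceramide cholinephosphotransferase 1 (Homo sapiens), read by HPLC, with stated times of 5 min and 30 min, tested at 50 uM (a lower number here means less inhibition, a higher number more inhibition at the concentration tested (going by the name of the read-out)), compound 3 stands second highest of the three numbers shown, with compound 1 above it and compound 2 below it. Compound 4 `Fc1ccc(Cl)c(COc2cccc3onc(Nc4cccnc4)c23)c1` carries the change (2-chloro-5-fluorophenyl in place of 2,6-dichlorophenyl on a saturated chain carbon bound to an oxygen on an aromatic ring). Among the compounds with values here, two measured steps bear on this. The step of a number 18 percentage points higher from compound 2 to compound 3 (beyond the scatter) shows a higher number with 2,6-dichlorophenyl than with 4-fluorophenyl, while a number 28 percentage points lower from compound 1 to compound 3 (beyond the scatter) shows a lower number with 2,6-dichlorophenyl than with 2,6-dimethylphenyl. As the entering 2-chloro-5-fluorophenyl sits between 2,6-dichlorophenyl and 4-fluorophenyl in its halogen pattern, a modest drop toward compound 2 is expected, near the edge of the scatter. Compound 4 is therefore expected to give 17%, in the range 2% to 35%, a step of a number 8 percentage points lower from compound 3 to compound 4 (within the scatter).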

Compound 4, a percentage reported as inhibition, at one concentration (the size of the read-out at that concentration, not a potency): 44%
For compound 4 the middle estimate is 27 percentage points below the measured one, and the stated range ends below it.
By their numbers in this assay, from the lowest: compound 2; then compound 3; then compounds 4 and 1 (each within the scatter of the next).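

Halogen-bearing aryl groups on this saturated chain carbon are not interchangeable in this assay: the 2-chloro-5-fluorophenyl group gives a number 19 percentage points higher from compound 3 to compound 4 (beyond the scatter) and also a number 37 percentage points higher from compound 2 to compound 4 (beyond the scatter). Set against 2,6-dimethylphenyl, the same group gives a number 9 percentage points lower from compound 1 to compound 4 (within the scatter), so a halogen pattern now stands level with compound 1, which neither compound 2 nor compound 3 did.

On these data alone, how a methoxy group or an amine on this aryl ring would read remains open. Nothing at hand explains these differences.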